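The compounds below may be only part of what the source reports. "The series", "measured", "known", "first", "only" and "open" are said of these compounds alone.

Measured compounds:
compound 1, `Cn1nc(-c2ccc(OC[C@H]3CC[C@H](N)CC3)c(F)c2)c2cnc(N)nc21`: 1400 nM
compound 2, `Cc1cc(-c2ccnc3[nH]ncc23)cnc1OCC12CCC(O)(CC1)CC2`: > 5000 nM

In an assay on tissue (PBMC cells) for antagonist activity at Toll-like receptor 9 (Homo sapiens) (on this read-out higher numbers stand for weaker inhibition and lower numbers for stronger inhibition), compound 2 reaches only a limit of the assay, > 5000 nM. That is the limit of > 5000 nM in this assay, at which 1 of the 2 values shown sits. Compound 1 gives 1400 nM in this assay. Compound 3, `Cc1cc(-c2ccnc3[nH]ncc23)cnc1OCC12CCC(N)(CC1)CC2`, differs from compound 2 by amino in place of hydroxy on a saturated ring carbon. Among the compounds with values here, no measured step covers this change, so its size is uncertain; since compound 1 also carries an amino group and gives 1400 nM, a move toward stronger inhibition, beyond the scatter, is expected. Compound 3 is estimated at 2000 nM, between 500 nM and 8000 nM. The expected step is an at least 2.5-fold lower number from compound 2 to compound 3 (0.39 log units; beyond the scatter).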

Compound 3, half-maximal inhibitory concentration: 1000 nM
Beside the measured number, compound 3's estimate is 2.0-fold (0.30 log units) above it; measured number inside the range.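

On a saturated ring carbon of a six-membered ring that is part of a fused or bridged system of two rings, amino in place of hydroxy gives an at least 5.0-fold lower number from compound 2 to compound 3 (0.69 log units; beyond the scatter). This exchange of one heavy atom for another, with the same counts of hydrogen-bond donors and acceptors, is enough to move the read-out beyond the scatter. Compound 2 stands at a limit and not at a number, so the full size of this step stays open: the limit of > 5000 nM in this assay, at which 1 of the 3 values shown sits.

The compounds shown leave open how a methylamino group, an aminomethyl group or a carboxylic acid would read at this carbon.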